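Swapping a ring amine for dimethylamino on the aryl group

The source may hold more compounds than are shown below. What is called first, only, known or untested is meant among the compounds shown, and "the series" means these compounds.

Compound 1 `OC1CNCc2nc(-c3ccc(N4CCCC4)cc3)sc21` gives 1070 nM in a functional assay on cells (Homo sapiens) for cytotoxicity, read by sulforhodamine B assay, with a stated time of 2 days; a higher number here means a weaker inhibitor, a lower number a stronger inhibitor. Compound 2 `Cc1cc(N(C)C)ccc1-c1nc2c(s1)[C@@H](O)CCC2` gives 1160 nM in this assay, a number within the scatter of the value of compound 1. Compound 3 `CN(C)c1ccc(-c2nc3c(s2)C(O)CNC3)cc1` has not been measured; it differs from compound 1 by dimethylamino in place of pyrrolidin-1-yl on an aromatic carbon. The expected step is a 1.2-fold higher number from compound 1 to compound 3 (0.08 log units; within the scatter), none beyond the scatter, because compound 2 also carries a dimethylamino group and gives 1160 nM. Compound 3 is therefore estimated at 1300 nM in this assay, with a range from 500 nM to 3500 nM.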

Compound 3, half-maximal inhibitory concentration: 1630 nM
Beside the measured number, compound 3's estimate is 1.3-fold (0.10 log units) below it; the measured number falls inside the stated range.
By their numbers in this assay, from the lowest: compounds 1, 2 and 3 (each within the scatter of the next).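

Replacing pyrrolidin-1-yl with dimethylamino on this aromatic carbon gives a 1.5-fold higher number from compound 1 to compound 3 (0.18 log units; within the scatter) in this assay. Going by these compounds alone, this is the first direct comparison at this position, where the two groups cannot be told apart in this assay. A ring on this nitrogen is therefore not needed for a number of this size in the shared core. Nothing measured here offers a reason for this result. Still open, going by these compounds, is whether morpholin-4-yl, a primary amine or methoxy on the same carbon would give a step beyond the scatter.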